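From methoxy to fluoro in a cytotoxicity series

A few compounds are considered here, and "the series" means these few. Any claim that something is new, unique, unknown or untested is made for them only; others in the source may bear on it.

Measured in a functional assay on UACC-62 cells (Homo sapiens) for cytotoxicity, read by MTT assay, with a stated time of 6 days; a higher number here means a weaker inhibitor, a lower number a stronger inhibitor:
- compound 1 `CC(=O)N[C@@H](CSC(=O)Nc1ccccc1Cl)C(=O)O` gives > 200000 nM (a limit of the assay, not a number)
- compound 2 `COc1ccc(NC(=O)SC[C@H](NC(C)=O)C(=O)O)cc1` gives 75200 nM
- compound 3 `CC(=O)N[C@@H](CSC(=O)Nc1cccc(Cl)c1)C(=O)O` gives > 200000 nM (a limit of the assay, not a number)

Among the compounds with values here, of these three, compound 2 is the only one with an actual number, 75200 nM. Compound 1 and compound 3 reach only limits, so they cannot be placed exactly against it.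

The next step leads to compound 4 `CC(=O)N[C@@H](CSC(=O)Nc1ccc(F)cc1)C(=O)O`, which has fluoro in place of methoxy on an aromatic carbon, para to a large group. The count of that change is fluoro in place of methoxy on an aromatic carbon.

Within the data shown here, no two measured compounds differ in one place only, so this assay offers no direct guide to the size of this step. Compound 1 and compound 3 both carry chloro and give no number, which leans the expectation modestly toward weaker inhibition, though a change within the usual scatter remains possible. The expected change is a 1.7-fold higher number from compound 2 to compound 4 (0.24 log units; within the scatter). For compound 4 the estimated value is 130000 nM, with an expected range from 45000 nM to 200000 nM.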

Compound 4, half-maximal inhibitory concentration: 36 nM
Estimate against measurement, compound 4: 3600-fold (3.56 log units) above; measured number below the stated range.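

The step shows that this place on the aromatic ring, para to a large group, matters greatly in this assay: fluoro in place of methoxy gives a 2100-fold lower number from compound 2 to compound 4 (3.32 log units; beyond the scatter). So a very small edit, with the 2 heavy atoms of methoxy giving way to the 1 heavy atom of fluoro, is enough to carry the number far beyond the scatter. No other step between these compounds can be read, because the remaining values give no number to compare: the limit of > 200000 nM in this assay, at which 2 of the 4 values shown sit.

As far as these compounds go, what stays open is whether fluoro itself brings this drop or whether removing methoxy is enough. A plain hydrogen or an amine at this same place would help separate the two, and a single step cannot show whether the effect would carry over to other groups.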